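The source may hold more compounds than are shown below. What is called first, only, known or untested is meant among the compounds shown, and "the series" means these compounds.

Measured compounds:
- compound 1, `ClCc1ccc(Cn2cnc3c(Cl)ncnc32)cc1`, 3460 nM
- compound 2, `ClCc1ccccc1Cn1cnc2c(Cl)nc(Cl)nc21`, 360 nM

Two compounds were tested in a functional assay on LOX IMVI cells (Homo sapiens) for cytotoxicity, read by sulforhodamine B assay, with a stated time of 48 h; on this read-out lower numbers stand for stronger inhibition of growth and higher numbers for weaker inhibition of growth. Compound 2 gives the lowest of the two numbers; the nearest, compound 1, gives a value that stands well beyond the scatter above it, so compound 2 is the stronger inhibitor of growth of the two. No pair of these compounds differs in only one place, so no single-change step can be read from them.

Compound 3, `ClCc1ccccc1Cn1cnc2c(Cl)ncnc21`, has not yet been measured in this assay . It differs from compound 2 in one place: hydrogen in place of chloro on an aromatic carbon. Among the compounds with values here, the chloro that leaves is one of the two chloro groups on the core of compound 2; compound 1 also carries only one chloro on its core, but it differs from compound 3 elsewhere as well, so it offers no direct guide to the size of this step.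

Within the data shown here, with no measured step of this kind, the expectation rests on the general picture: the chloro that leaves is lost from the more potent compound, and the number for compound 3 is expected to rise modestly, by a step of a 3.3-fold higher number from compound 2 to compound 3 (0.52 log units; beyond the scatter). Compound 3 is therefore estimated at 1200 nM, within a range from 400 nM to 4000 nM.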

Compound 3, concentration for total growth inhibition: 5240 nM
For compound 3 the middle estimate is 4.4-fold (0.64 log units) below the measured one; the measured number lies above the stated range.
By their numbers in this assay, from the lowest: compound 2; then compounds 1 and 3 (each within the scatter of the next).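

In this assay, the chloro on the aromatic carbon between two ring nitrogen atoms turns out to matter a great deal to compound 2: hydrogen in its place gives a 15-fold higher number from compound 2 to compound 3 (1.16 log units; beyond the scatter). Within the data shown here, this is the first change that can be read at a single place, since compounds 1 and 2 differ in more than one place and could not separate the effect of this chloro from that of the rest of the structure. The step shows that this one position on the core can by itself move the number by a large amount, though no measurement shown here accounts for its size.

Going by these compounds, whether chloro is specifically needed at this position remains open, since fluoro, bromo, an amine or a methoxy group at the same carbon would be needed to tell whether other groups can take its place. On these data alone, it is also open whether the other chloro on the core or the chloromethyl group matters as much, and whether this step carries over to cells other than those of this single assay.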